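Ethoxy for tert-butyl on the aryl ring of a pyrrole acid

The compounds below may be only part of what the source reports. "The series", "measured", "known", "first", "only" and "open" are said of these compounds alone.

Measured compounds:
Compound 1 `Cc1cc(C(=O)O)c(C)n1-c1cccc(C2CC2)c1` gives 580 nM in an assay on cells for inhibition of Palmitoleoyl-protein carboxylesterase NOTUM variant C330S (Homo sapiens), read by fluorescence, with a stated time of 40 min; on this read-out higher numbers stand for weaker inhibition and lower numbers for stronger inhibition.
Compound 2 `Cc1cc(C(=O)O)c(C)n1-c1cccc(C(C)C)c1` gives 360 nM in this assay.
Compound 3 `Cc1cc(C(=O)O)c(C)n1-c1cccc(C(C)(C)C)c1` gives 460 nM in this assay.

The three compounds share one core and differ only in the group on the six-membered aromatic ring. Compound 3 sits among them with no separation that the assay can resolve: a 1.3-fold lower number from compound 1 to compound 3 (0.10 log units; within the scatter) and a 1.3-fold higher number from compound 2 to compound 3 (0.11 log units; within the scatter), and likewise a 1.6-fold lower number from compound 1 to compound 2 (0.21 log units; within the scatter). Every swap measured so far, then, has moved the number by no more than the scatter.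

Compound 4 `CCOc1cccc(-n2c(C)cc(C(=O)O)c2C)c1` takes the same core with the change (ethoxy in place of tert-butyl on an aromatic carbon). Within the data shown here, none of the measured steps exchanges a carbon group for one that carries an oxygen, so the steps bear on this change only loosely; they show that the ring position tolerates several groups of similar size without a step beyond the scatter. On that basis compound 4 is expected to stay near compound 3, with a 1.2-fold higher number from compound 3 to compound 4 (0.08 log units; within the scatter) as the estimated step, though the entering oxygen leaves the direction open. For compound 4 the estimate in this assay is 550 nM, with a range from 200 nM to 1600 nM.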

Compound 4, half-maximal inhibitory concentration: 640 nM
Estimate against measurement, compound 4: 1.2-fold (0.07 log units) below, within the range that was stated.
By their numbers in this assay, from the lowest: compounds 2, 3, 1 and 4 (each within the scatter of the next).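

In this assay, among these compounds, putting ethoxy, the only group here that carries an oxygen, on this aromatic carbon gives no step that the assay can resolve against any of the three carbon groups (a 1.4-fold higher number from compound 3 to compound 4 (0.14 log units; within the scatter); a 1.8-fold higher number from compound 2 to compound 4 (0.25 log units; within the scatter); a 1.1-fold higher number from compound 1 to compound 4 (0.04 log units; within the scatter)). The position therefore accepts a hydrogen-bond acceptor in the entering group, as well as the carbon-only groups, with all four compounds within the scatter of one another. No measurement shown here explains this result.

The compounds shown leave open whether an amine, a carboxylic acid or a longer chain such as hexyl at this position would give a step beyond the scatter. They also leave open whether methoxy or a hydroxyl group would behave as ethoxy does.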